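The source may hold more compounds than are shown below. What is called first, only, known or untested is meant among the compounds shown, and "the series" means these compounds.

Compound 2 `COc1ccc(-c2cn(Cc3ccc(F)cc3)c(=O)c(C(=O)NC3CCCCCC3)c2-c2ccccc2)cc1` is the starting point. In an assay on HEK293 cells for inhibition of Lysophosphatidylserine lipase ABHD12 (Homo sapiens), with stated times of 30 min and 5 min (on this read-out higher numbers stand for weaker inhibition and lower numbers for stronger inhibition), compound 2 gives > 10000 nM, which is a limit of the assay rather than a number. Compound 1 `COc1ccc(-c2cn(Cc3ccc(F)cc3)c(=O)c(C(=O)NC3CCCCCC3)c2C)cc1` differs from compound 2 by phenyl in place of methyl on an aromatic carbon. In this assay compound 1 gives > 10000 nM, also a limit. The step that the two limits leave unreadable from compound 1 to compound 2 therefore has no readable size because of the limit of > 10000 nM in this assay, at which 2 of the 2 values shown sit. Compound 3 `O=C(NC1CCCCCC1)c1c(-c2ccccc2)c(-c2ccccc2)cn(Cc2ccc(F)cc2)c1=O` carries the change (hydrogen in place of methoxy on an aromatic carbon); cut one bond further out, a 4-methoxyphenyl becomes a phenyl. Going by the values given here, no measured step shows a readable size for such a change. The expected step that the limit leaves unreadable from compound 2 to compound 3 is therefore small. Compound 3 is estimated at 20000 nM, within 7000 nM to 60000 nM.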

Compound 3, half-maximal inhibitory concentration: > 10000 nM
Compound 3: a limit, no number (the forecaster's own chance of this, stated with the estimate: 80%); the middle value lies beyond the limit too.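

No size can be read for the step between compound 2 and compound 3, since both values are limits rather than numbers: (the limit of > 10000 nM in this assay, at which 3 of the 3 values shown sit). The compounds shown leave open how strongly any of them inhibits the enzyme, and whether either change affects that inhibition.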